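A few compounds are considered here, and "the series" means these few. Any claim that something is new, unique, unknown or untested is made for them only; others in the source may bear on it.

Measured compounds:
compound 1, `COc1ccccc1/C=C1\CCC/C(=C\c2ccc(OC)c(OC)c2)C1=O`: 8100 nM
compound 2, `COc1cccc(/C=C2\CCC/C(=C\c3ccc(OC)c(OC)c3)C2=O)c1`: 4600 nM

Both values come from a functional assay on HT-1080 cells (Homo sapiens) for cytotoxicity, read by MTT assay, with a stated time of 72 h; on this read-out higher numbers stand for weaker inhibition and lower numbers for stronger inhibition. On these two numbers compound 2 holds the lowest, but the step of a 1.8-fold lower number from compound 1 to compound 2 (0.25 log units; within the scatter) lies within the usual scatter, so the two compounds cannot be told apart by their cytotoxicity.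

Compound 3, `COc1ccc(/C=C2\CCC/C(=C\c3cc(Cl)cc(Cl)c3)C2=O)cc1OC`, has not yet been measured in this assay. It differs from compound 2 in one place: 3,5-dichlorophenyl in place of 3-methoxyphenyl on a double-bonded chain carbon bound to a double-bonded ring carbon. Within the data shown here, the only measured step, from compound 1 to compound 2, moves the methoxy group within the same kind of phenyl ring and stays within the scatter; no measured step exchanges a methoxyphenyl for a dichlorophenyl, so there is no direct guide for this change. With nothing in the data pointing either way, the expected step of a 1.3-fold lower number from compound 2 to compound 3 (0.12 log units; within the scatter) is taken as small, with a wide margin on both sides. For compound 3 in this assay the estimated value is 3500 nM, expected to fall between 1000 nM and 12000 nM.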

Compound 3, half-maximal inhibitory concentration: 3000 nM
The estimate for compound 3 lay 1.2-fold (0.07 log units) above the measured number, within the range that was stated.
By their numbers in this assay, from the lowest: compounds 3, 2 and 1 (each within the scatter of the next, the first and the last beyond it).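

Exchanging 3-methoxyphenyl for 3,5-dichlorophenyl on a double-bonded chain carbon bound to a double-bonded ring carbon gives, in this assay, a result that stays close to that of the methoxy compound (a 1.5-fold lower number from compound 2 to compound 3 (0.19 log units; within the scatter)), so at this place a group with 0 hydrogen-bond acceptors can stand in for one with 1 without a change that can be told from the scatter. Set against the 2-methoxyphenyl group, the same 3,5-dichlorophenyl group gives the first step here that clears the scatter, though only modestly (a 2.7-fold lower number from compound 1 to compound 3 (0.43 log units; beyond the scatter)). Nothing measured on these compounds offers a reason for either step.

What the compounds shown leave open is whether the chlorine atoms themselves matter or whether losing the methoxy group is enough, a question that a plain phenyl or a 3-chlorophenyl group at the same place would bear on. Going by these compounds, it also remains open how this place would respond to a quite different kind of group, such as an amine or a carboxylic acid on the phenyl ring.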